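Methyl for Methoxy on the Outer Phenyl Ring

The compounds below may be only part of what the source reports. "The series", "measured", "known", "first", "only" and "open" are said of these compounds alone.

Measured in a functional assay on HT-29 cells (Homo sapiens) for cytotoxicity, read by MTT assay, with a stated time of 72 h; on this read-out higher numbers stand for weaker inhibition and lower numbers for stronger inhibition:
- compound 1 `COc1cc2c(Oc3ccc(NC(=O)c4cc(-c5ccc(C(F)(F)F)cc5)ccn4)cc3F)ccnc2cc1OCCCN1CCCCC1`: 230 nM
- compound 2 `COc1ccc(-c2ccnc(C(=O)Nc3ccc(Oc4ccnc5cc(OCCCN6CCCCC6)c(OC)cc45)c(F)c3)c2)cc1`: 690 nM
- compound 3 `COc1ccc(-c2ccnc(C(=O)Nc3ccc(Oc4ccnc5cc(OCCCN6CCN(C)CC6)c(OC)cc45)c(F)c3)c2)cc1`: 390 nM

Compound 2 carries the highest number of the three, which on this read-out means the weakest inhibition. Its nearest neighbour is compound 3, reached by a 1.8-fold lower number from compound 2 to compound 3 (0.25 log units; within the scatter), a difference that does not exceed the usual scatter. The farthest is compound 1, from which compound 2 is reached by a 3.0-fold higher number from compound 1 to compound 2 (0.48 log units; beyond the scatter), a difference that does exceed the scatter.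

Compound 4 `COc1cc2c(Oc3ccc(NC(=O)c4cc(-c5ccc(C)cc5)ccn4)cc3F)ccnc2cc1OCCCN1CCCCC1` is the next compound. Compared with compound 2 it differs in one place: methyl in place of methoxy on an aromatic carbon. For the measured compounds named here, only one measured step concerns this same position, the step of a 3.0-fold higher number from compound 1 to compound 2 (0.48 log units; beyond the scatter), where a methoxy replaced a trifluoromethyl and the number rose modestly. The step of a 1.8-fold lower number from compound 2 to compound 3 (0.25 log units; within the scatter) concerns a different part of the molecule and says little here. Going by the values given here, no measured pair shows methyl against methoxy directly, so the direction rests on the single comparison with compound 1.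

The expected step from compound 2 to compound 4 is a 1.7-fold lower number from compound 2 to compound 4 (0.24 log units; within the scatter), a modest lowering at most. Compound 4 is estimated at 400 nM in this assay, within a range from 150 nM to 1100 nM.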

Compound 4, half-maximal inhibitory concentration: 340 nM
For compound 4 the middle estimate is 1.2-fold (0.07 log units) above the measured one; measured number inside the range.
By their numbers in this assay, from the lowest: compounds 1, 4, 3 and 2 (each within the scatter of the next, the first and the last beyond it).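

In this assay, for the compounds shown here, the change from methoxy to methyl gives a 2.0-fold lower number from compound 2 to compound 4 (0.31 log units; beyond the scatter), the first direct comparison of these two groups at this position, and the modest step lies beyond the usual scatter. Replacing trifluoromethyl with methyl at the same position gives a 1.5-fold higher number from compound 1 to compound 4 (0.17 log units; within the scatter), which lies within the scatter, so compound 1 and compound 4 cannot be told apart here, while methoxy in compound 2 stands apart from both with a higher number. Nothing measured here accounts for this difference between the groups.

Among the compounds shown, methyl and trifluoromethyl at this position appear only with the piperidin-1-yl chain, so it remains open whether the same pattern would hold with the 4-methylpiperazin-1-yl chain of compound 3. From the compounds shown here alone, it also remains open where a plain hydrogen, a chlorine atom, a nitrile or a carboxylic acid at this position would fall relative to these three groups.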